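The compounds below may be only part of what the source reports. "The series", "measured", "known", "first", "only" and "open" are said of these compounds alone.

Measured in a functional assay on ileum (Cavia porcellus) for antagonist activity, with a stated time of 30 s; a lower number here means a stronger inhibitor, a higher number a weaker inhibitor:
- compound 1 `O=C(O)c1cc(=O)c2ccc(OCCCOc3ccccc3)cc2o1`: 1.4 ug/mL
- compound 2 `O=C(O)c1cc(=O)c2ccc(OCCCCCOc3ccccc3)cc2o1`: 0.4 ug/mL
- compound 3 `O=C(O)c1cc(=O)c2ccc(OCCCCCCCOc3ccccc3)cc2o1`: 1.8 ug/mL

Compound 2 has the lowest number of the three, and its gaps to both neighbours lie beyond the scatter. The move to compound 4 `CC(=O)c1ccc(OCCCCCOc2ccc3c(=O)cc(C(=O)O)oc3c2)cc1O` keeps the chain of compound 2 and changes the end group: 4-acetyl-3-hydroxyphenyl in place of phenyl on an oxygen on a saturated carbon. This is 4-acetyl-3-hydroxyphenyl in place of phenyl on an oxygen on a saturated carbon.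

Going by the values given here, no measured step covers this change. Among the compounds with values here, the only size guides are chain steps: a 3.5-fold lower number from compound 1 to compound 2 (0.54 log units; beyond the scatter) and a 4.5-fold higher number from compound 2 to compound 3 (0.65 log units; beyond the scatter), both modest. Within the data shown here, a modest step in this assay is therefore expected, tentatively towards a lower number, though no measured compound supports that direction. The expected step is a 2.7-fold lower number from compound 2 to compound 4 (0.43 log units; beyond the scatter). For compound 4 the estimated value is 0.15 ug/mL, with an expected range of 0.03 ug/mL to 0.7 ug/mL.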

Compound 4, half-maximal inhibitory concentration: 6.8 ug/mL
Compound 4: the middle estimate sits 45-fold (1.66 log units) below what was measured, outside the stated range (above it).
By their numbers in this assay, from the lowest: compound 2; then compounds 1 and 3 (each within the scatter of the next); then compound 4.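

In this assay, the chain length was the only variable so far, and each chain step was modest; changing the end group on the same chain now gives a 17-fold higher number from compound 2 to compound 4 (1.23 log units; beyond the scatter), a large step. The oxygen-linked end group is therefore a sensitive position, and here a substituted phenyl ranks behind the plain phenyl of compound 2. Nothing available accounts for this step.

Open, as far as these compounds go, is whether the acetyl or the hydroxy alone would give a step of this size, since both enter together. Also open, from the compounds shown here alone, is how 4-methoxyphenyl would read on this chain, and whether the chain steps hold with 4-acetyl-3-hydroxyphenyl at the end.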